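Indole acrylonitrile sulfone series: methoxy removal

The source may report more compounds than this note shows. Statements on the series, on what has been measured and on what is new or still open speak of the compounds shown alone.

Measured compounds:
- compound 1 `CC(=O)/C(=C\c1c(-c2ccccc2)[nH]c2ccccc12)S(=O)(=O)c1ccccc1`: 1700 nM
- compound 2 `O=C(/C(=C\c1c(-c2ccccc2)[nH]c2ccccc12)S(=O)(=O)c1ccccc1)c1ccccc1`: 7800 nM
- compound 3 `COc1ccc2[nH]c(-c3ccccc3)c(/C=C(\C#N)S(=O)(=O)c3ccccc3)c2c1`: 7400 nM

In a functional assay on COLO 205 cells (Homo sapiens) for inhibition, read by sulforhodamine B assay, with a stated time of 48 h (a higher number here means a weaker inhibitor of growth, a lower number a stronger inhibitor of growth), compound 3 sits second highest of the three numbers; its value lies within the scatter of compound 2 and is separated from compound 1 by a gap beyond the scatter. Compound 4 `N#C/C(=C\c1c(-c2ccccc2)[nH]c2ccccc12)S(=O)(=O)c1ccccc1` differs from compound 3 by hydrogen in place of methoxy on an aromatic carbon. Going by the values given here, the only measured step, a 4.6-fold higher number from compound 1 to compound 2 (0.66 log units; beyond the scatter), concerns the carbonyl substituent and does not touch the aromatic ring changed here, so no measured step bears on this change. Without a precedent, no shift beyond the scatter is expected; the estimated step is a 1.1-fold lower number from compound 3 to compound 4 (0.06 log units; within the scatter). Compound 4 is therefore expected to give about 6500 nM, with a range from 2500 nM to 17000 nM in this assay.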

Compound 4, concentration for 50% growth inhibition: 1400 nM
Compound 4: middle estimate off by 4.6-fold (0.67 log units), on the high side, and the stated range ends above it.
By their numbers in this assay, from the lowest: compounds 4 and 1 (each within the scatter of the next); then compounds 3 and 2 (each within the scatter of the next).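

In this assay, going by these compounds alone, hydrogen in place of methoxy on this aromatic carbon gives the first measured step at this position (a 5.3-fold lower number from compound 3 to compound 4 (0.72 log units; beyond the scatter)), and the change is beyond the scatter. With hydrogen on that carbon, cyano can be compared with both carbonyl groups on the chain carbon: benzoyl gives way to cyano with a gain (a 5.6-fold lower number from compound 2 to compound 4 (0.75 log units; beyond the scatter)), whereas acetyl and cyano stay within the scatter (a 1.2-fold lower number from compound 1 to compound 4 (0.08 log units; within the scatter)). No measurement shown accounts for the methoxy step.

As far as these compounds go, whether an amine, a carboxylic acid or a longer alkoxy chain on the same aromatic carbon would track hydrogen or methoxy remains open. So does whether the methoxy step holds with acetyl or benzoyl in place of cyano.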